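The compounds below may be only part of what the source reports. "The series", "measured", "known", "first", "only" and "open" are said of these compounds alone.

In a functional assay on NCI-H460 cells (Homo sapiens) for cytotoxicity, read by MTT assay, with a stated time of 72 h (a lower number here means a stronger inhibitor, a higher number a weaker inhibitor), three compounds have been measured:

Compound 1 `COc1cc2c(Oc3ccc(NC(=O)c4nccc(-c5ccc(C)cc5)n4)cc3F)ccnc2cc1OCCCN1CCCCC1` gives 230 nM in this assay.
Compound 2 `COc1cc2c(Oc3ccc(NC(=O)c4nccc(-c5ccc(F)cc5)n4)cc3F)ccnc2cc1OCCCN1CCCCC1` gives 240 nM in this assay.
Compound 3 `COc1cc2c(Oc3ccc(NC(=O)c4nccc(-c5ccc(C)cc5)n4)cc3F)ccnc2cc1OCCCN1CCN(C)CC1` gives 160 nM in this assay.

Compound 1 and compound 2 share their core and differ by fluoro in place of methyl on an aromatic carbon. That change gave a 1.0-fold higher number from compound 1 to compound 2 (0.02 log units; within the scatter). The cores of compound 1 and compound 3 differ by 4-methylpiperazin-1-yl in place of piperidin-1-yl on a saturated chain carbon, three bonds along the chain from an oxygen on an aromatic ring, a change that gave a 1.4-fold lower number from compound 1 to compound 3 (0.16 log units; within the scatter). Compound 4 `COc1cc2c(Oc3ccc(NC(=O)c4nccc(-c5ccc(F)cc5)n4)cc3F)ccnc2cc1OCCCN1CCN(C)CC1` has not been measured in this assay; it differs from compound 3 by fluoro in place of methyl on an aromatic carbon, the same change that leads from compound 1 to compound 2, made on the same place on the core of compound 3. Because the earlier step of a 1.0-fold higher number from compound 1 to compound 2 (0.02 log units; within the scatter) was within the scatter, the step from compound 3 to compound 4 is expected to be a 1.1-fold higher number from compound 3 to compound 4 (0.03 log units; within the scatter), again within the scatter. Compound 4 is therefore estimated to give 170 nM in this assay, with a likely range from 90 nM to 330 nM.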

Compound 4, half-maximal inhibitory concentration: 63 nM
Estimate against measurement, compound 4: 2.7-fold (0.43 log units) above, outside the stated range (below it).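

In this assay, fluoro in place of methyl gave a 2.5-fold lower number from compound 3 to compound 4 (0.40 log units; beyond the scatter), a step beyond the scatter where the earlier one was not, yet the gap between the two steps does not exceed what two such steps can scatter: the same change on two cores in this assay, a 1.0-fold higher number (0.02 log units; within the scatter) from compound 1 to compound 2 and a 2.5-fold lower number (0.40 log units; beyond the scatter) from compound 3 to compound 4, 2.7-fold (0.42 log units) apart, within the scatter of two such steps. The exchange of piperidin-1-yl for 4-methylpiperazin-1-yl gave a 3.8-fold lower number from compound 2 to compound 4 (0.58 log units; beyond the scatter), and here too the gap to the earlier step stays within that scatter: the same change on two cores in this assay, a 1.4-fold lower number (0.16 log units; within the scatter) from compound 1 to compound 3 and a 3.8-fold lower number (0.58 log units; beyond the scatter) from compound 2 to compound 4, 2.7-fold (0.42 log units) apart, within the scatter of two such steps. Within the data shown here, each change can therefore be carried from one core to the other without a demonstrable difference in its step, but with only two steps per change this does not show that the steps are equal, nor that the two changes reinforce each other in compound 4.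

The compounds shown leave open how chloro or methoxy would behave in place of fluoro on the phenyl ring. They also leave open whether a morpholin-4-yl group in place of 4-methylpiperazin-1-yl, or a longer chain, would give steps of similar size.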